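This account rests on a few compounds, and the source may have more. Where it says the series, first, only, none or still open, it means among the compounds named here.

The study measures three compounds in an assay on cells for inhibition of HSP60/HSP10 (Homo sapiens), with a stated time of 60 min (on this read-out lower numbers stand for stronger inhibition and higher numbers for weaker inhibition), and asks what a fourth will do. Among the compounds with values here, compound 1 `O=S(=O)(Nc1ccc(-c2nc3ccccc3o2)cc1)c1ccc(Cl)c(C(F)(F)F)c1` gives 12000 nM in this assay, the only numeric reading of the set. Compound 3 `O=S(=O)(Nc1ccc(-c2nc3ccccc3o2)cc1)c1ccccc1F` reaches only a limit of this assay, > 100000 nM, which is a bound of the measurement rather than a number. Compound 2 `Cc1ccc(S(=O)(=O)Nc2ccc3oc(-c4ccccc4)nc3c2)cc1` likewise sits at a limit, giving > 100000 nM in this assay. Most of the set therefore rests at the limit of > 100000 nM in this assay, at which 2 of the 3 values shown sit. Within the data shown here, compound 2 thus stands at the weak end of what the test can report, with no numeric value of its own and no measured step leading to or from it. Compound 4 `COc1ccc(Cl)cc1S(=O)(=O)Nc1ccc2oc(-c3ccccc3)nc2c1` has not yet been tested. It differs from compound 2 by 5-chloro-2-methoxyphenyl in place of 4-methylphenyl on a sulfonyl sulfur. Among the measured compounds shown here, no measured pair of compounds covers a change of this kind. The step of a number no higher from compound 2 to compound 4 (the limit leaves the size open) is expected to be none beyond the scatter. Compound 4 is expected to give about 100000 nM, within a range from 25000 nM to 400000 nM, and most likely again only as a limit.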

Compound 4, half-maximal inhibitory concentration: > 100000 nM
Compound 4 ended at the assay's limit (the forecaster's own chance of this, stated with the estimate: 60%); the middle value lies on the limit itself.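

Within the data shown here, compound 2 and compound 4 both rest at a limit of this assay, and no step between them can be read. The compounds shown leave open whether 5-chloro-2-methoxyphenyl in place of 4-methylphenyl on a sulfonyl sulfur changes inhibition at all.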